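Replacing one fluoro with hydrogen on compound 2

The source may report more compounds than this note shows. Statements on the series, on what has been measured and on what is new or still open speak of the compounds shown alone.

In an in vivo ADME assay on the whole organism (strain Wistar) for metabolic stability, with Rattus norvegicus as the target, at a dose of 100 mg/kg by the oral route (on this read-out higher numbers stand for a longer-lived compound and lower numbers for a shorter-lived compound), compound 1 (`CCC(=O)NS(=O)(=O)c1ccc(-n2nc(C(F)F)cc2-c2ccc(Br)cc2)cc1CO`) gives 7.42 h and compound 2 (`CCC(=O)NS(=O)(=O)c1ccc(-n2nc(C(F)(F)F)cc2-c2ccc(OC)c(C)c2)cc1CO`) gives 6.82 h, two values within the usual scatter of each other. Compound 3 (`CCC(=O)NS(=O)(=O)c1ccc(-n2nc(C(F)F)cc2-c2ccc(OC)c(C)c2)cc1CO`) differs from compound 2 by hydrogen in place of fluoro on a saturated chain carbon bound to an aromatic carbon and two fluorine atoms, trifluoromethyl to difluoromethyl. Among the measured compounds shown here, no measured pair isolates this change. Starting from compound 2 at 6.82 h, no shift beyond the scatter is expected in this assay, and the expected step of a 1.0-fold higher number from compound 2 to compound 3 (0.01 log units; within the scatter) is small. For compound 3 the estimated value is 7 h, with an expected range of 4.5 h to 11 h.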

Compound 3, half-life: 5.92 h
Compound 3: the middle estimate sits 1.2-fold (0.07 log units) above what was measured, within the range that was stated.
By their numbers in this assay, from the lowest: compounds 3, 2 and 1 (each within the scatter of the next).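

In this assay, trifluoromethyl to difluoromethyl gives a 1.2-fold lower number from compound 2 to compound 3 (0.06 log units; within the scatter), so this pair places hydrogen in place of fluoro on this carbon without a difference that can be told from the scatter. With difluoromethyl held in place, 4-methoxy-3-methylphenyl in place of 4-bromophenyl gives a 1.3-fold lower number from compound 1 to compound 3 (0.10 log units; within the scatter), which likewise cannot be told from the scatter. Nothing available explains either result.

Going by these compounds, whether the fluoro change reads the same alongside 4-bromophenyl remains open. So does the half-life with a nitrile or a carboxylic acid at this position.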